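Swapping the Benzyl Substituent: Methyl Gives Way to Methoxy

The source may hold more compounds than are shown below. What is called first, only, known or untested is meant among the compounds shown, and "the series" means these compounds.

Three compounds have been measured in an assay on CHO cells for displacement of a labelled ligand from Alpha-1A adrenergic receptor (Homo sapiens); on this read-out lower numbers stand for stronger inhibition and higher numbers for weaker inhibition:
Compound 1 `COc1cccc(OC)c1OCCNCCOc1ccccc1OCc1ccccc1Cl`: 1.41 nM
Compound 2 `COc1cccc(OC)c1OCCNCCOc1ccccc1OCc1ccccc1C`: 1.59 nM
Compound 3 `COc1cccc(OC)c1OCCNCCOc1ccccc1OCc1ccccc1[N+](=O)[O-]`: 7.94 nM

Compound 2 stands second highest of the three in this assay; compound 1 sits within the scatter of it, while compound 3 lies beyond. Compound 4 `COc1cccc(COc2ccccc2OCCNCCOc2c(OC)cccc2OC)c1` differs from compound 2 by 3-methoxyphenyl in place of 2-methylphenyl on a saturated chain carbon bound to an oxygen on an aromatic ring. The known steps all change the group on the benzyl ring: a 1.1-fold higher number from compound 1 to compound 2 (0.05 log units; within the scatter), a 5.0-fold higher number from compound 2 to compound 3 (0.70 log units; beyond the scatter) and a 5.6-fold higher number from compound 1 to compound 3 (0.75 log units; beyond the scatter). None of them introduces a methoxy group on this ring, so they only bound the expectation. Since chloro and methyl are interchangeable while nitro costs modestly, compound 4 is expected to show at most a small rise, a 1.9-fold higher number from compound 2 to compound 4 (0.28 log units; within the scatter). Compound 4 is therefore estimated at 3 nM, within 1 nM to 9 nM.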

Compound 4, inhibition constant: 2 nM
Compound 4: the middle estimate sits 1.5-fold (0.18 log units) above what was measured; the range from low to high includes it.
By their numbers in this assay, from the lowest: compounds 1, 2 and 4 (each within the scatter of the next); then compound 3.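

In this assay, 3-methoxybenzyl at this position reads level with the 2-methyl and 2-chloro benzyl groups (a 1.3-fold higher number from compound 2 to compound 4 (0.10 log units; within the scatter)) (a 1.4-fold higher number from compound 1 to compound 4 (0.15 log units; within the scatter)). The modest loss seen with the nitro group does not carry over to this methoxy group (a 4.0-fold lower number from compound 3 to compound 4 (0.60 log units; beyond the scatter)). No evidence at hand bears on this result.

Compound 4 changes both the group and its place on the benzyl ring, so the two changes cannot be told apart. As far as these compounds go, how 2-methoxybenzyl, or an amine or carboxylic acid on this ring, would read remains open.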